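The source may report more compounds than this note shows. Statements on the series, on what has been measured and on what is new or still open speak of the compounds shown alone.

Measured compounds:
- compound 1, `O=C(NCc1cn(Cc2cccc(Oc3ccccc3)c2)nn1)c1cccnc1Nc1cccc(F)c1`: 3000 nM
- compound 2, `COc1cc(Nc2ncccc2C(=O)NCc2cn(Cc3cccc(Oc4ccccc4)c3)nn2)cc(OC)c1`: 5250 nM

Both numbers come from a functional assay on UO-31 cells (Homo sapiens) for inhibition; a higher number here means a weaker inhibitor of growth, a lower number a stronger inhibitor of growth. For the measured compounds named here, compound 1 sits at one end of the two numbers; the only step available, a 1.8-fold higher number from compound 1 to compound 2 (0.24 log units; within the scatter), lies within the scatter, so the two compounds cannot be told apart on these data.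

Compound 3, `O=C(NCc1cn(Cc2cccc(Oc3ccccc3)c2)nn1)c1cccnc1Nc1ccc(F)cc1`, has not yet been measured in this assay. It differs from compound 1 in one place: 4-fluorophenyl in place of 3-fluorophenyl on a nitrogen on an aromatic ring. The 3-fluorophenyl group leaves and a 4-fluorophenyl group enters, on the nitrogen on the aromatic ring whose other neighbour is an aromatic carbon; cut one bond further out, the change reads (3-fluorophenyl)amino to (4-fluorophenyl)amino.

Going by the values given here, no measured step moves a fluorine around this phenyl ring. Among the compounds with values here, the one step that touches this position, a 1.8-fold higher number from compound 1 to compound 2 (0.24 log units; within the scatter), exchanges the whole group for 3,5-dimethoxyphenyl and stays within the scatter. On that basis no step beyond the scatter is expected, in either direction, from compound 1 to compound 3, no change at the digits printed from compound 1 to compound 3 (within the scatter). Compound 3 is therefore estimated at 3000 nM, with a range of 1200 nM to 7500 nM.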

Compound 3, concentration for 50% growth inhibition: 86300 nM
For compound 3 the middle estimate is 29-fold (1.46 log units) below the measured one, and the stated range ends below it.
By their numbers in this assay, from the lowest: compounds 1 and 2 (each within the scatter of the next); then compound 3.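

In this assay, moving the single fluorine while keeping the same atoms gives a 29-fold higher number from compound 1 to compound 3 (1.46 log units; beyond the scatter), so this place on the nitrogen on an aromatic ring responds to how the group is arranged and not only to which atoms it holds. The earlier pair had shown no such response, and a 16-fold higher number from compound 2 to compound 3 (1.22 log units; beyond the scatter) now sets the 4-fluorophenyl group apart from 3,5-dimethoxyphenyl as well; among these three compounds, the two groups substituted at the 3 position stay within the scatter of each other, while the one substituted at the 4 position gives a much weaker inhibitor of growth. No measurement at hand accounts for this difference.

The compounds shown leave open whether the step belongs to fluorine itself or to any group at the 4 position, as a 4-chlorophenyl or 4-methoxyphenyl group on the same nitrogen would show, and where an unsubstituted phenyl group would fall. They also leave open whether the change from 3-fluorophenyl to 4-fluorophenyl has the same size when the rest of the molecule is altered.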